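The compounds below may be only part of what the source reports. "The series", "measured", "known", "first", "only" and "open" are said of these compounds alone.

Measured so far:
compound 1 `C/C(=N\O)c1ccc2[nH]c(-c3ccc(C(F)(F)F)cc3)nc2c1`: "not determined" (no result reported)
compound 2 `C/C(=N\NC(N)=S)c1ccc2[nH]c(-c3ccc(Cl)cc3)nc2c1`: 2000 nM

Among the compounds with values here, in an ADME assay on MT4 cells (Homo sapiens) for cytotoxicity, read by MTT assay, with a stated time of 96 h (a lower number here means that less compound is tolerated, a higher number that more compound is tolerated), compound 2 gives 2000 nM, the only number, so it cannot yet be ranked against anything. Compound 1 has no reported result and offers no comparison. The next compound to be tested is compound 3 `C/C(=N\NC(N)=S)c1ccc2[nH]c(-c3ccc(C(F)(F)F)cc3)nc2c1`, which carries trifluoromethyl in place of chloro on an aromatic carbon, para to a large group: trifluoromethyl in place of chloro on an aromatic carbon. Within the data shown here, no measured step shows what this exchange does in this assay. The expectation therefore rests on compound 2 at 2000 nM alone, and no change beyond the usual scatter is expected in either direction. The expected step is a 1.3-fold higher number from compound 2 to compound 3 (0.10 log units; within the scatter). For compound 3 the estimated value is 2500 nM, with an expected range of 900 nM to 8000 nM.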

Compound 3, half-maximal cytotoxic concentration: 2000 nM
Compound 3: middle estimate off by 1.3-fold (0.10 log units), on the high side; the range from low to high includes it.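

At this position, para to a large group, the exchange now has a first reading: in this assay trifluoromethyl in place of chloro on an aromatic carbon gives no change at the digits printed from compound 2 to compound 3 (within the scatter) on the shared core. The larger of the two groups, at 4 heavy atoms against 1, thus leaves the read-out unmoved in this single pair, which is no basis for a wider pattern. No measured property of either group bears on this result, and the flat step remains unexplained.

Going by these compounds, whether the same position tolerates a different kind of group, such as an amine, a carboxylic acid or a longer chain, remains open. On these data alone, the step from compound 1 to compound 3 cannot be read, so the contribution of the other substituent on the shared core in this assay is also open.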